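Compound 3: shortening the acid chain on the amine

A few compounds are considered here, and "the series" means these few. Any claim that something is new, unique, unknown or untested is made for them only; others in the source may bear on it.

Values in an ADME assay on MRC5 cells (Homo sapiens) for cytotoxicity, read by MTT assay, with a stated time of 72 h; on this read-out higher numbers stand for weaker inhibition and lower numbers for stronger inhibition:
Compound 1 `CSCC[C@H](NC1=CC(=O)C=C(C[C@]2(C)[C@@H](C)CC[C@]3(C)C(C)=CCC[C@@H]23)C1=O)C(=O)O`: > 200000 nM (a limit)
Compound 2 `CC1=CCC[C@H]2[C@](C)(CC3=CC(=O)C=C(NCCC(=O)O)C3=O)[C@@H](C)CC[C@]12C`: 80800 nM
Compound 3 `CC1=CCC[C@H]2[C@](C)(CC3=CC(=O)C=C(NCC(=O)O)C3=O)[C@@H](C)CC[C@]12C`: not yet measured

Going by the values given here, compound 2, at 80800 nM, holds the only actual number in this assay so far. Compound 1 stands at the limit of > 200000 nM in this assay, at which 1 of the 2 values shown sits.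

Compound 3 differs from compound 2 by carboxy in place of carboxymethyl on a saturated chain carbon bound to an amine nitrogen. Among the compounds with values here, one measured step bears on this change, an at least 2.4-fold lower number from compound 1 to compound 2 (0.39 log units; beyond the scatter), with 2-carboxyethyl in place of 1-carboxy-3-(methylsulfanyl)propyl on the same amine nitrogen. Going by these compounds, it lies beyond the scatter, and its full size is unknown since one end is a limit. In compound 3, as in compound 1, carboxy sits on a saturated chain carbon bound to an amine nitrogen, so part of an at least 2.4-fold lower number from compound 1 to compound 2 (0.39 log units; beyond the scatter) is expected to reverse. The change is smaller than in that step, so only a slight shift toward a higher number is expected, probably not beyond the scatter. The estimated step is a 1.4-fold higher number from compound 2 to compound 3 (0.13 log units; within the scatter). Compound 3 is expected at 110000 nM, with an estimated range from 50000 nM to 200000 nM.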

Compound 3, half-maximal inhibitory concentration: 183000 nM
For compound 3 the middle estimate is 1.7-fold (0.22 log units) below the measured one; measured number inside the range.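

In this assay, the length of the acid chain on the amine nitrogen matters on its own: carboxy in place of carboxymethyl on a saturated chain carbon bound to an amine nitrogen, which turns the 2-carboxyethyl chain into carboxymethyl, gives a 2.3-fold higher number from compound 2 to compound 3 (0.36 log units; beyond the scatter). The earlier step changed chain length and the 2-(methylsulfanyl)ethyl branch together, whereas hydrogen in place of 2-(methylsulfanyl)ethyl now gives an at least 1.0-fold lower number from compound 1 to compound 3 (0.03 log units; that floor lies within the scatter), so no effect of that branch can be read, and compound 2 keeps the lowest number of the three in this assay. The value of compound 1 is a limit, so this last step has only a floor: the limit of > 200000 nM in this assay, at which 1 of the 3 values shown sits.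

Still open, going by these compounds, is whether a longer chain, such as 3-carboxypropyl on the same amine nitrogen, would lower the number further or whether 2-carboxyethyl is the best length in this short run. Also open, on these data alone, is how much the carboxylic acid itself contributes, which a primary amide or a methyl ester at the end of the 2-carboxyethyl chain would show.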